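The source may report more compounds than this note shows. Statements on the series, on what has been measured and on what is new or still open speak of the compounds shown alone.

Compound 1, with the structure `CC(=O)Cn1nnnc1Cc1ccc(-c2ccccc2)cc1`, and compound 2, with the structure `CN(C)C(=O)Cn1nnc(CNC(=O)c2ccc(-c3ccccc3)cc2)n1`, were both tested in a functional assay on HEK293 cells for agonist activity at transient receptor potential cation channel subfamily V member 1 (Homo sapiens), read by calcium flux; a lower number here means that less compound is needed, a higher number that more compound is needed for the effect. For compound 1 the result is not a number but a limit of this assay, > 100000 nM. For compound 2 the result is likewise only a limit, > 100000 nM. Among the compounds with values here, compound 2 therefore stands at the limit of this assay, a position it shares with the only other value shown, as summarised by the limit of > 100000 nM in this assay, at which 2 of the 2 values shown sit: both measured compounds sit there, and no number separates them.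

Compound 3, with the structure `CC(C)Cn1nnc(CNC(=O)c2ccc(-c3ccccc3)cc2)n1`, has not yet been measured in this assay. It differs from compound 2 in one place: isopropyl in place of dimethylcarbamoyl on a saturated chain carbon bound to an aromatic nitrogen, which, cut one bond further out, reads as (dimethylcarbamoyl)methyl to isobutyl. Within the data shown here, no measured pair shows what this change does.

With both known compounds at the limit, compound 3 is expected to remain there as well, with the step of a number no higher from compound 2 to compound 3 (the limit leaves the size open) showing no shift beyond the scatter. For compound 3 the estimated half-maximal effective concentration is 100000 nM, expected to lie between 20000 nM and 500000 nM.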

Compound 3, half-maximal effective concentration: 53500 nM
Compound 3: the middle estimate sits 1.9-fold (0.27 log units) above what was measured, within the range that was stated.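

In this assay compound 3 gives a number rather than a limit, 53500 nM, so a substituent at this place, on a saturated chain carbon bound to an aromatic nitrogen, can carry a response that can be read within the range of the assay. Placing isopropyl there instead of dimethylcarbamoyl amounts to an at least 1.8-fold lower number from compound 2 to compound 3 (0.27 log units; that floor lies within the scatter); this figure is only a floor set by the limit of compound 2, so the true size of the step remains unknown and may or may not exceed the scatter. The two earlier compounds give limits of the assay and not numbers: the limit of > 100000 nM in this assay, at which 2 of the 3 values shown sit.

The compounds shown do not tell whether an n-butyl chain, a longer alkyl chain, a cyclohexyl group or an amine at this place would lower the number further or return it to the limit. Going by these compounds, compound 1 differs from compound 3 in more than one place, so it cannot show what the isobutyl group contributes on its own, and whether the same change would give a number on another core stays open.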